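Trading an Indane for a Trifluoromethoxyphenyl Group

A few compounds are considered here, and "the series" means these few. Any claim that something is new, unique, unknown or untested is made for them only; others in the source may bear on it.

Of the compounds shown here, three sharing one core have been tested in a functional assay on cells (Hepatocyte, Homo sapiens) for inhibition, with a stated time of 10 min; a higher number here means a weaker inhibitor, a lower number a stronger inhibitor. Compound 1 `O=C(O)CCNC(=O)c1ccc(CN(c2ccc3c(c2)CCC3)c2nc(-c3ccc(C(F)(F)F)cc3)cs2)cc1` returned only a limit there, < 20000 nM, and so its true potency is not pinned down. Compound 2 `O=C(O)CCNC(=O)c1ccc(CN(c2ccc3c(c2)CCCC3)c2nc(-c3ccc(Cl)c(Cl)c3)cs2)cc1` gives 4000 nM in this assay, and compound 3 `O=C(O)CCNC(=O)c1ccc(CN(c2ccc(C(F)(F)F)cc2)c2nc(-c3ccc(Cl)cc3)cs2)cc1` gives 6700 nM; these two values lie within the usual scatter of each other. Compound 1 thus stands apart only in that its result is the limit noted as the limit of < 20000 nM in this assay, at which 1 of the 3 values shown sits, and nothing connects it directly to the two measured numbers.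

Compound 4 `O=C(O)CCNC(=O)c1ccc(CN(c2ccc(OC(F)(F)F)cc2)c2nc(-c3ccc(C(F)(F)F)cc3)cs2)cc1` differs from compound 1 in one place: 4-(trifluoromethoxy)phenyl in place of 2,3-dihydro-1H-inden-5-yl on a nitrogen on an aromatic ring. Among the measured compounds shown here, no measured pair in this set follows the same change, so the step has no precedent here. Compound 1 is known only as a limit, and the step from it cannot be sized from the data. The expected step that the limit leaves unreadable from compound 1 to compound 4 is therefore anchored to the measured compounds rather than to compound 1 itself. Taking compound 3, which gives 6700 nM in this assay, as the nearest guide, compound 4 is expected to give about 6000 nM, with a plausible range from 1500 nM to 25000 nM.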

Compound 4, half-maximal inhibitory concentration: 3600 nM
The estimate for compound 4 lay 1.7-fold (0.22 log units) above the measured number, and the stated range covers the measured number.
By their numbers in this assay, from the lowest: compounds 4, 2 and 3 (each within the scatter of the next).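

No new step can be read between compound 1 and compound 4, because compound 1 is known only as a limit: the limit of < 20000 nM in this assay, at which 1 of the 4 values shown sits.

The compounds shown leave open how far 4-(trifluoromethoxy)phenyl in place of 2,3-dihydro-1H-inden-5-yl shifts potency in this assay.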